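From hydroxy to propoxy on the shared core

The source may hold more compounds than are shown below. What is called first, only, known or untested is meant among the compounds shown, and "the series" means these compounds.

Three measured compounds share one core that carries a carboxylic acid and differ only within that core. Compound 1 `CC(C)c1onc(-c2c(Cl)cccc2Cl)c1COc1ccc(-c2ccc3c(C(=O)O)ccnc3c2)cc1` gives 340 nM in a functional assay for agonist activity at Bile acid receptor (Homo sapiens), read by FRET; on this read-out lower numbers stand for an effect already at smaller amounts and higher numbers for an effect only at larger amounts of compound. Compound 2 `CC(C)c1onc(-c2c(Cl)cccc2Cl)c1COc1ccc(-c2ccc3nc(C(=O)O)nnc3c2)cc1` gives 360 nM in this assay. Compound 3 `CC(C)c1onc(-c2c(Cl)cccc2Cl)c1COc1ccc(-c2ccc3nc(C(=O)O)cc(O)c3c2)cc1` gives 51 nM in this assay, the lowest of the three numbers; its nearest neighbour is compound 1, and the gaps to both compound 1 and compound 2 lie beyond the usual scatter.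

Compound 4 `CCCOc1cc(C(=O)O)nc2ccc(-c3ccc(OCc4c(-c5c(Cl)cccc5Cl)noc4C(C)C)cc3)cc12` has not yet been measured. It differs from compound 3 in a single place: propyl in place of hydrogen on an oxygen on an aromatic ring. Within the data shown here, no measured pair shows this change, so the step from compound 3 to compound 4 has no direct precedent among the numbers in hand. The three measured compounds do show that what sits on the shared core can move the number beyond the scatter, so a real shift is possible. The expected step is a 1.3-fold lower number from compound 3 to compound 4 (0.11 log units; within the scatter), within the scatter or a little lower. Compound 4 is estimated at 40 nM, with a range from 12 nM to 150 nM.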

Compound 4, half-maximal effective concentration: 59 nM
The estimate for compound 4 lay 1.5-fold (0.17 log units) below the measured number, and the stated range covers the measured number.
By their numbers in this assay, from the lowest: compounds 3 and 4 (each within the scatter of the next); then compounds 1 and 2 (each within the scatter of the next).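

Replacing hydroxy with propoxy on the shared core gives a 1.2-fold higher number from compound 3 to compound 4 (0.06 log units; within the scatter) in this assay, so this read-out does not separate the two groups at this place. The earlier compounds shown here held no change at this oxygen on an aromatic ring; this pair shows that a propyl can stand there in place of hydrogen without moving the number beyond the scatter. Nothing in hand bears on why the two compounds read alike.

From the compounds shown here alone, a single pair cannot show how far this tolerance extends, so it remains open how a methyl, a butyl or a longer chain on the same oxygen would read. Going by these compounds, it also remains open whether an amine in place of that oxygen would keep the number within the scatter of compound 3.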